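This account rests on a few compounds, and the source may have more. Where it says the series, first, only, none or still open, it means among the compounds named here.

Compound 1 `CCCc1nc2cc(C(=O)N3CCC4(CC3)CC(=O)N(c3ccc(C(F)(F)F)cc3)C4)cc(C)c2[nH]1`: > 10000 nM (a limit of the assay, not a number)
Compound 2 `O=C(c1ccc2[nH]c(-c3ccccc3)nc2c1)N1CCC2(CC1)CC(=O)N(c1ccc(C(F)(F)F)cc1)C2`: 1920 nM

Both compounds were tested in a functional assay on A549 cells (Homo sapiens) for antiproliferative activity, read by MTT assay, with a stated time of 48 h; on this read-out higher numbers stand for weaker inhibition and lower numbers for stronger inhibition. Going by the values given here, compound 2 gives the only true number so far, 1920 nM, so it is the one firm reference point. The result for compound 1 is only a limit, so it offers no exact distance to compare.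

Compound 3 `O=C(c1ccc2[nH]c(-c3ccco3)nc2c1)N1CCC2(CC1)CC(=O)N(c1ccc(C(F)(F)F)cc1)C2` keeps everything in compound 2 except one group: it has furan-2-yl in place of phenyl on an aromatic carbon, between two ring nitrogen atoms (furan-2-yl in place of phenyl on an aromatic carbon). Among the compounds with values here, no measured pair of compounds shows what this swap does in this assay, so the forecast starts from compound 2 at 1920 nM. One aromatic ring replaces another and the rest of the molecule stays the same. The expectation is therefore a small step, most likely none beyond the scatter, with a slight lean toward weaker inhibition. The expected change is a 1.3-fold higher number from compound 2 to compound 3 (0.11 log units; within the scatter). Compound 3 is estimated at 2500 nM, with an expected range from 800 nM to 8000 nM.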

Compound 3, half-maximal inhibitory concentration: 7960 nM
Compound 3: middle estimate off by 3.2-fold (0.50 log units), on the low side; measured number inside the range.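

Swapping phenyl for furan-2-yl on this aromatic carbon, between two ring nitrogen atoms, gives a 4.1-fold higher number from compound 2 to compound 3 (0.62 log units; beyond the scatter) in this assay, so this position does respond to the ring it carries, which the earlier compounds could not show without a matched pair. The swap replaces a six-membered aromatic ring of carbon only with a five-membered aromatic ring holding one oxygen, and in this single pair the number moves toward weaker inhibition, modestly but beyond the scatter. Further weakening in this series could soon stop yielding a number, as with compound 1, whose result is a limit and not a number: the limit of > 10000 nM in this assay, at which 1 of the 3 values shown sits.

This one pair cannot separate the effect of ring size from that of the oxygen, and nothing shown explains why the number rises. A thiophene-2-yl ring, with sulfur in place of the oxygen, or a pyridine ring, which keeps six ring atoms but holds a nitrogen, would help pull these apart, and a phenyl carrying an amine or a carboxylic acid could show whether this position can also move the number the other way.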